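Swapping a pyridine ring for a pyrrole ring

The source may report more compounds than this note shows. Statements on the series, on what has been measured and on what is new or still open speak of the compounds shown alone.

Compound 2 `CCN(Cc1cccnc1)C(=O)COc1ccc(C)cc1` is one of two measured members of a small series tested in an assay on HEK293 cells for agonist activity at transient receptor potential cation channel subfamily M member 8 (Homo sapiens), read by fluorescence and calcium flux, with a stated time of 15 min; on this read-out lower numbers stand for an effect already at smaller amounts and higher numbers for an effect only at larger amounts of compound. Among the compounds with values here, compound 2 gives 15400 nM, the highest number of the two; its only measured neighbour, compound 1 `CCN(Cc1cncs1)C(=O)COc1ccc(C)cc1`, gives 1100 nM in this assay. Within the data shown here, the single known step, a 14-fold higher number from compound 1 to compound 2 (1.15 log units; beyond the scatter), links a five-membered ring to a six-membered one with a much larger number. Compound 3 `CCN(Cc1cc[nH]c1)C(=O)COc1ccc(C)cc1` takes the next step: 1H-pyrrol-3-yl in place of pyridin-3-yl on a saturated chain carbon bound to an amide-type nitrogen. This again exchanges the six-membered ring for a five-membered one, though the newcomer carries a hydrogen-bond donor where the old ring carried an acceptor. Compound 3 is expected to move downward, a 3.9-fold lower number from compound 2 to compound 3 (0.59 log units; beyond the scatter), because the step of a 14-fold higher number from compound 1 to compound 2 (1.15 log units; beyond the scatter) rose sharply when the six-membered ring came in, though the two five-membered rings differ, so a smaller move is expected. Compound 3 is therefore estimated at 4000 nM, within 1000 nM to 15000 nM in this assay.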

Compound 3, half-maximal effective concentration: 21800 nM
For compound 3 the middle estimate is 5.5-fold (0.74 log units) below the measured one, outside the stated range (above it).
By their numbers in this assay, from the lowest: compound 1; then compounds 2 and 3 (each within the scatter of the next).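

In this assay, the exchange of pyridin-3-yl for 1H-pyrrol-3-yl gives a 1.4-fold higher number from compound 2 to compound 3 (0.15 log units; within the scatter), so this position does not separate these two groups, even though the ring size and the counts of hydrogen-bond donors and acceptors both change. A five-membered aromatic ring alone is therefore not enough to give the low number of compound 1: the change from 1,3-thiazol-5-yl to 1H-pyrrol-3-yl gives a 20-fold higher number from compound 1 to compound 3 (1.30 log units; beyond the scatter), and among these three compounds only the 1,3-thiazol-5-yl group stands apart. Nothing measured here gives a reason for these numbers.

As far as these compounds go, it remains open whether a thiophen-3-yl ring or a plain phenyl ring at this place would group with compound 1 or with compounds 2 and 3. From the compounds shown here alone, it is also open whether the same ranking would hold if the shared core were changed elsewhere.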